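A Sulfur for an Oxygen on Compound 2

The compounds below may be only part of what the source reports. "The series", "measured", "known", "first", "only" and "open" are said of these compounds alone.

Of the compounds shown here, three have numbers so far in a functional assay on HL-60 cells (Homo sapiens) for inhibition, read by CCK-8 assay, with a stated time of 48 h; on this read-out lower numbers stand for stronger inhibition and higher numbers for weaker inhibition. Compound 2 `O=C(NCCNS(=O)(=O)c1ccc(-c2ccccc2O[C@H]2CC[C@H](O)CC2)s1)Nc1ccc([N+](=O)[O-])cc1` stands highest at 8900 nM, which makes it the weakest of the three. Compound 1 `O=S(=O)(NCCNC(=S)Nc1cccc(Cl)c1)c1ccc(-c2ccccc2OCc2cccc(O)c2)s1` gives 1800 nM, and compound 3 `O=C(NCCNS(=O)(=O)c1ccc(-c2ccccc2Oc2ccc([N+](=O)[O-])c([N+](=O)[O-])c2)s1)Nc1ccc([N+](=O)[O-])cc1` gives 340 nM.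

Compound 4 `O=[N+]([O-])c1ccc(NC(=S)NCCNS(=O)(=O)c2ccc(-c3ccccc3O[C@H]3CC[C@H](O)CC3)s2)cc1` awaits measurement. It differs from compound 2 in one place: a group of 12 heavy atoms (7 carbon, 2 nitrogen, 2 oxygen, 1 sulfur; one six-membered aromatic ring of carbon only) in place of a group of 12 heavy atoms (7 carbon, 2 nitrogen, 3 oxygen; one six-membered aromatic ring of carbon only), on an amine nitrogen. By the count, one sulfur replaces one oxygen.

Among the measured compounds shown here, the only measured step, a 26-fold lower number from compound 2 to compound 3 (1.42 log units; beyond the scatter), is large, but it lies elsewhere, on an oxygen on an aromatic ring, so it does not size this change. For the measured compounds named here, no measured step covers the change on the amine nitrogen. Going by the values given here, a weak hint comes from compound 1 at 1800 nM, a number lower than that of compound 2, though this gap is no clean step.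

A modest move to a lower number, near the edge of the scatter, is expected, estimated as a 2.0-fold lower number from compound 2 to compound 4 (0.30 log units; within the scatter). Compound 4 is expected at 4500 nM, with an estimated range from 1500 nM to 12000 nM.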

Compound 4, half-maximal inhibitory concentration: 11600 nM
The estimate for compound 4 lay 2.6-fold (0.41 log units) below the measured number, and the stated range covers the measured number.
By their numbers in this assay, from the lowest: compound 3; then compound 1; then compounds 2 and 4 (each within the scatter of the next).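

In this assay, among the compounds shown here, the first measured change on the amine nitrogen is a 1.3-fold higher number from compound 2 to compound 4 (0.12 log units; within the scatter), so one sulfur for one oxygen in this group leaves the read-out within the scatter. For the compounds shown here, the only earlier step, a 26-fold lower number from compound 2 to compound 3 (1.42 log units; beyond the scatter), lay on an oxygen on an aromatic ring; this position, with the 4-hydroxycyclohexyl group kept in place, now has a measured step of its own, and that step does not separate the two compounds. No measured evidence bears on this result.

Going by these compounds, whether the same exchange stays this small with the 3,4-dinitrophenyl group of compound 3 remains open. Also open, on these data alone, is what an amine or a carboxylic acid in place of the nitro group of the 4-nitrophenyl ring would do to the read-out.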